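From methylamino to amino on the shared core

The source may hold more compounds than are shown below. What is called first, only, known or untested is meant among the compounds shown, and "the series" means these compounds.

Measured in a functional assay on SW480 cells (Homo sapiens) for antiproliferative activity, read by MTT assay, with a stated time of 48 h (a lower number here means a stronger inhibitor, a higher number a weaker inhibitor), for three compounds:
Compound 1 `CCCCC(CCO)n1cnc2c(N)ncnc21` gives > 50000 nM as a limit
Compound 2 `CCCCCCC(CCO)n1cnc2c(Cl)ncnc21` gives 16700 nM as a number
Compound 3 `CCCCCCC(CCO)n1cnc2c(NC)ncnc21` gives > 50000 nM as a limit

Compound 3 stands at the limit of > 50000 nM in this assay, at which 2 of the 3 values shown sit, and so has a limit and no number. Compound 4 `CCCCCCC(CCO)n1cnc2c(N)ncnc21` swaps one group, with hydrogen in place of methyl on a nitrogen on an aromatic ring, counted as hydrogen in place of methyl on a nitrogen on an aromatic ring in full. For the measured compounds named here, the one measured step, an at least 2.9-fold higher number from compound 2 to compound 3 (0.47 log units; beyond the scatter) for methylamino in place of chloro, is a different change and guides this one only loosely. The amino group also stands on compound 1 at > 50000 nM as a limit, though that compound differs elsewhere. No step beyond the scatter is therefore expected in this assay and no direction is favoured. The expected change is an at least 1.1-fold lower number from compound 3 to compound 4 (0.04 log units; that floor lies within the scatter) in this estimate. For compound 4 the estimated value is 45000 nM within a range of 18000 nM to 100000 nM and a limit is quite possible.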

Compound 4, half-maximal inhibitory concentration: > 50000 nM
Compound 4 was reported as a limit; the forecaster's own chance of this, stated with the estimate: 55%; middle value at least 1.1-fold (0.04 log units) away from the limit.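

In this assay compound 4 gives > 50000 nM, which is a limit and not a number. Going from chloro to amino there is an at least 2.9-fold higher number from compound 2 to compound 4 (0.47 log units; beyond the scatter), so in this assay amino, like methylamino, gives no number, whereas chloro does. The steps to compound 4 from compound 3 and from compound 1 cannot be read, because both ends of each are limits: the limit of > 50000 nM in this assay, at which 3 of the 4 values shown sit.

From the compounds shown here alone, whether losing the methyl changes anything therefore stays open. So does how a methoxy or a dimethylamino group on that aromatic carbon would compare with chloro in this assay.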